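The compounds below may be only part of what the source reports. "The series", "measured", "known", "first", "only" and "open" are said of these compounds alone.

Measured so far in a functional assay on HCT-116 cells (Homo sapiens) for antiproliferative activity, read by MTT assay, with a stated time of 72 h; a higher number here means a weaker inhibitor, a lower number a stronger inhibitor:
- compound 1 `NC1=NC2(CCOCC2)N(OCCCOc2ccccc2)C(N)=N1`: 6010 nM
- compound 2 `NC1=NC2(CCSCC2)N(OCCCOc2cccc(Cl)c2Cl)C(N)=N1`: 1 nM

Only these two compounds have been measured in this assay. Compound 1, at 6010 nM, has the higher number and is therefore the weaker inhibitor of the pair. Compound 2, at 1 nM, lies far lower, and this gap is well beyond the scatter. Within the data shown here, no measured step between compounds differing in one place is available, so the gap cannot be assigned to any single structural change.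

Compound 3 `NC1=NC2(CCOCC2)N(OCCCOc2ccc(Cl)cc2Cl)C(N)=N1` departs from compound 1 in one place: 2,4-dichlorophenyl in place of phenyl on an oxygen on a saturated carbon. In words, it has 2,4-dichlorophenyl in place of phenyl on an oxygen on a saturated carbon.

A large step to a lower number is expected in this assay, though its size is uncertain. This expectation rests on compound 2 at 1 nM, which shows how low a number can go in this small set. The expected change is a 150-fold lower number from compound 1 to compound 3 (2.18 log units; beyond the scatter). For compound 3 the estimate is 40 nM, with an expected range from 3 nM to 600 nM.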

Compound 3, half-maximal inhibitory concentration: 880 nM
For compound 3 the middle estimate is 22-fold (1.34 log units) below the measured one, and the stated range ends below it.
By their numbers in this assay, from the lowest: compound 2; then compound 3; then compound 1.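

In this assay, among these compounds, the change to 2,4-dichlorophenyl in place of phenyl on an oxygen on a saturated carbon is the first single-place step that can be read, and it gives a 6.8-fold lower number from compound 1 to compound 3 (0.83 log units; beyond the scatter) with the rest of compound 1 held fixed. This shows that the number responds to a change at this position, with a step that is modest in size yet beyond the scatter, although this reading rests on a single pair of compounds. Nothing measured here gives any explanation for the step.

The compounds shown leave open whether both chlorine atoms of the 2,4-dichlorophenyl group are needed, or whether a single chlorine, a fluorine, a methoxy group or a carboxylic acid on the phenyl ring would move the number in the same direction or by a similar amount. They also leave open how the same change would behave on a different core, and whether a longer chain or a shorter chain in place of the present one would alter the size of this step.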